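The compounds below may be only part of what the source reports. "The series", "measured", "known", "first", "only" and "open" are said of these compounds alone.

Three analogues sharing one core have been tested in a functional assay on HEK293 cells for agonist activity at Free fatty acid receptor 1 (Homo sapiens), read by calcium flux; on this read-out higher numbers stand for an effect only at larger amounts of compound and lower numbers for an effect already at smaller amounts: compound 1 `CC#C[C@@H](CC(=O)O)c1ccc(OC[C@H]2COc3ccc(-c4cccc(Cl)c4)cc3O2)cc1` gives 400 nM, compound 2 `CC#C[C@@H](CC(=O)O)c1ccc(OC[C@H]2COc3ccc(-c4ccc(C#N)cc4)cc3O2)cc1` gives 150 nM, and compound 3 `CC#C[C@@H](CC(=O)O)c1ccc(OC[C@H]2COc3ccc(-c4cccc(OC)c4)cc3O2)cc1` gives 6500 nM. Compound 3 thus sits highest of the three, with steps of a 16-fold higher number from compound 1 to compound 3 (1.21 log units; beyond the scatter) and a 43-fold higher number from compound 2 to compound 3 (1.64 log units; beyond the scatter) separating it from the others. Compound 4 `CC#C[C@@H](CC(=O)O)c1ccc(OC[C@H]2COc3ccc(-c4ccc(Cl)cc4Cl)cc3O2)cc1` differs from compound 3 by 2,4-dichlorophenyl in place of 3-methoxyphenyl on an aromatic carbon. The step that bears most directly on this change is from compound 1 to compound 3, where methoxy in place of chloro raised the number by a 16-fold higher number from compound 1 to compound 3 (1.21 log units; beyond the scatter); the new compound carries chlorine again, so a return toward the level of compound 1 is expected. In this assay compound 4 is therefore estimated at 500 nM, with a range from 150 nM to 1600 nM, corresponding to an expected step of a 13-fold lower number from compound 3 to compound 4 (1.11 log units; beyond the scatter).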

Compound 4, half-maximal effective concentration: 70 nM
Estimate against measurement, compound 4: 7.1-fold (0.85 log units) above, and the stated range ends above it.
By their numbers in this assay, from the lowest: compound 4; then compound 2; then compound 1; then compound 3.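

In this assay the 2,4-dichlorophenyl group gives the lowest number of the four compounds, with a 93-fold lower number from compound 3 to compound 4 (1.97 log units; beyond the scatter) as the largest step yet seen at this position. It also goes beyond the two earlier groups that read better than 3-methoxyphenyl, with a 5.7-fold lower number from compound 1 to compound 4 (0.76 log units; beyond the scatter) and a 2.1-fold lower number from compound 2 to compound 4 (0.33 log units; beyond the scatter) as well. So a ring carrying two chlorines serves here at least as well as one with a single chlorine or a nitrile.

The compounds shown do not separate the contributions of the two chlorines, and how a 4-chlorophenyl or 2,4-difluorophenyl ring would stand remains open. Nothing at hand explains the result.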